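This account rests on a few compounds, and the source may have more. Where it says the series, first, only, none or still open, it means among the compounds named here.

This account follows compound 1 `COc1ccccc1NC(=S)N/N=C/c1ccc2ccccc2n1` toward compound 4 `COc1ccc(C)cc1NC(=S)N/N=C/c1ccc2ccccc2n1`. In a functional assay on HT-29 cells (Homo sapiens) for antiproliferative activity, read by sulforhodamine B assay, with a stated time of 72 h (on this read-out higher numbers stand for weaker inhibition and lower numbers for stronger inhibition), compound 1 reaches only a limit of the assay, > 100000 nM, which is not a number; this is recorded as the limit of > 100000 nM in this assay, at which 1 of the 3 values shown sits. Two further compounds accompany it. Compound 2 `CN(C)C(=S)N/N=C/c1cc2cccnc2s1` gives 13400 nM in this assay, and compound 3 `CN(C)C(=S)N/N=C/c1ccc2ccccc2n1` gives 20 nM in this assay; no step between any two of the three measured compounds is available, so their values are simply shown side by side. Compound 4 differs from compound 1 by methyl in place of hydrogen on an aromatic carbon, in words, methyl in place of hydrogen on an aromatic carbon. The step from compound 1 to compound 4 is expected to be none beyond the scatter, a number no higher from compound 1 to compound 4 (the limit leaves the size open). Compound 4 is therefore estimated at 100000 nM in this assay, within 30000 nM to 300000 nM, most likely reported again only as a limit.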

Compound 4, half-maximal inhibitory concentration: > 100000 nM
Compound 4 ended at the assay's limit; the forecaster's own chance of this, stated with the estimate: 80%; the middle value sits exactly at the limit.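

No new step can be read between compound 1 and compound 4, because both stop at a limit of the assay: the limit of > 100000 nM in this assay, at which 2 of the 4 values shown sit.

The compounds shown leave open whether methyl in place of hydrogen changes activity at all in this assay.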